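The compounds below may be only part of what the source reports. "The series", "measured", "known", "first", "only" and "open" are said of these compounds alone.

Of the compounds shown here, three built on the same core have been tested so far in a functional assay on the whole organism with Mus musculus as the target, with a stated time of 90 min, at a dose of 25 umol/kg by the oral route; a higher number here means a stronger effect of the compound at the dose given, a lower number a weaker effect. Compound 1 `Clc1nc(NC2CC2)c2ncn(C3CCCCO3)c2n1` carries only the cyclopropylamine on that core and gives 11.9%. Compound 2 `NC(=O)CC[C@H](NC(=O)CN(c1nc(Cl)nc2c1ncn2C1CCCCO1)C1CC1)C(=O)OCc1ccccc1` extends the nitrogen with a glycine unit capped by a glutamine benzyl ester and gives 37.8%. Compound 3 `O=C(OCc1ccccc1)[C@@H]1CCCN1C(=O)CN(c1nc(Cl)nc2c1ncn2C1CCCCO1)C1CC1` has the same glycine linker capped instead by a proline benzyl ester and gives 23.3%. Among these three numbers compound 2 stands highest: the nearest to it, compound 3, lies lower by a gap beyond the scatter, and the furthest, compound 1, lies lower still, also beyond the scatter.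

Compound 4 `C[C@@H](O)[C@H](NC(=O)CN(c1nc(Cl)nc2c1ncn2C1CCCCO1)C1CC1)C(=O)OCc1ccccc1` has not yet been measured. It differs from compound 2 in one place, (1-hydroxyethyl in place of 2-carbamoylethyl on a saturated chain carbon bound to an amide-type nitrogen and a carbonyl carbon). Both groups keep one hydrogen-bond donor and one acceptor, and the rest of the molecule is unchanged. Among the compounds with values here, no step between two measured compounds that differ in a single place is available, so the expectation rests on the closeness of the two structures. In this assay a small downward step, no larger than the scatter, is expected from compound 2 to compound 4, a number 6.8 percentage points lower from compound 2 to compound 4 (within the scatter). Compound 4 is therefore estimated at 31%, with a range from 16% to 46%.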

Compound 4, a percentage reported as activity, at one dose (the size of the read-out at that dose, not a potency): 23.4%
The estimate for compound 4 lay 7.6 percentage points above the measured number, and the stated range covers the measured number.
By their numbers in this assay, from the lowest: compound 1; then compounds 3 and 4 (each within the scatter of the next); then compound 2.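

Replacing 2-carbamoylethyl with 1-hydroxyethyl on a saturated chain carbon bound to an amide-type nitrogen and a carbonyl carbon gives the only single-place comparison among these compounds, and in this assay it reads as a number 14.4 percentage points lower from compound 2 to compound 4 (beyond the scatter). This shows that the number responds to the group at this position, even though the two groups have the same hydrogen-bond donor and acceptor counts, so matching those counts did not preserve the number of compound 2. The change also goes from 5 heavy atoms to 3, removes a double bond and adds a defined stereocentre, and nothing available here separates these differences or explains the drop.

The compounds shown leave open whether the step follows the size of the group or the replacement of the carbamoyl end by a hydroxyl, a question that a 3-hydroxypropyl group at the same place would address. They also leave open how a carboxylic acid at the end of the chain, as in a 2-carboxyethyl group, or a basic amine, as in a 4-aminobutyl group, would read in this assay.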